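A few compounds are considered here, and "the series" means these few. Any claim that something is new, unique, unknown or untested is made for them only; others in the source may bear on it.

For the measured compounds named here, in an assay on isolated protein for agonist activity at Bile acid receptor (Homo sapiens), read by TR-FRET (on this read-out lower numbers stand for an effect already at smaller amounts and higher numbers for an effect only at larger amounts of compound), compound 3 `CC(C)c1onc(-c2c(Cl)cccc2Cl)c1COc1ccc(-c2nc3ccc(C(=O)O)cc3n2CC2CCCCC2)cc1` gives 19.9 nM, the lowest of the three numbers measured so far. Compound 2 `CCCC(CCC)n1c(-c2ccc(OCc3c(-c4c(Cl)cccc4Cl)noc3C(C)C)cc2)nc2ccc(C(=O)O)cc21` gives 30.3 nM, and a 1.5-fold lower number from compound 2 to compound 3 (0.18 log units; within the scatter) stays within the usual scatter, while compound 1 `CC(C)c1onc(-c2c(Cl)cccc2Cl)c1COc1ccc(-c2nc3ccc(C(=O)O)cc3n2C2CC2)cc1` gives 117 nM and a 5.9-fold lower number from compound 1 to compound 3 (0.77 log units; beyond the scatter) lies beyond it. Compound 4 `CC(C)c1onc(-c2c(Cl)cccc2Cl)c1COc1ccc(-c2nc3ccc(C(=O)O)cc3n2C(C)C)cc1` differs from compound 3 by isopropyl in place of cyclohexylmethyl on an aromatic nitrogen. Going by the values given here, the steps that bear on this are a 5.9-fold lower number from compound 1 to compound 3 (0.77 log units; beyond the scatter) and a 3.9-fold lower number from compound 1 to compound 2 (0.59 log units; beyond the scatter), both modest and both toward lower numbers as the group on that nitrogen grew from cyclopropyl. Since isopropyl carries fewer heavy atoms than cyclohexylmethyl and sits closer to cyclopropyl in that count, a move back toward the number of compound 1 is expected, roughly a 3.0-fold higher number from compound 3 to compound 4 (0.48 log units; beyond the scatter). Compound 4 is therefore estimated at 60 nM, with a range from 25 nM to 150 nM.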

Compound 4, half-maximal effective concentration: 56.7 nM
Estimate against measurement, compound 4: 1.1-fold (0.02 log units) above, and the stated range covers the measured number.
By their numbers in this assay, from the lowest: compounds 3, 2 and 4 (each within the scatter of the next, the first and the last beyond it); then compound 1.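

Isopropyl on this aromatic nitrogen loses part of what cyclohexylmethyl reached, with a 2.8-fold higher number from compound 3 to compound 4 (0.45 log units; beyond the scatter), yet it remains distinct from cyclopropyl, with a 2.1-fold lower number from compound 1 to compound 4 (0.31 log units; beyond the scatter). Against 1-propylbutyl the change is a 1.9-fold higher number from compound 2 to compound 4 (0.27 log units; within the scatter), so these two open-chain groups are not told apart here. A ring on the nitrogen does not sort the numbers either, since compound 1 and compound 3 each carry one and lie at the two ends of the series.

Nothing available explains these differences. From the compounds shown here alone, how a phenyl ring, or a chain ending in an amine or a hydroxyl group, would behave on this nitrogen remains open.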